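Cytotoxicity of a methoxy-methylphenyl amide against colon cells

A few compounds are considered here, and "the series" means these few. Any claim that something is new, unique, unknown or untested is made for them only; others in the source may bear on it.

Compound 1 `CCc1ccc(NC(=O)c2cccc(/C=C3\CC(=O)N(c4ccccc4)C3=O)c2)cc1` was tested in an ADME assay on HCT-116 cells (Homo sapiens) for cytotoxicity, read by MTT assay, with a stated time of 72 h (on this read-out lower numbers stand for stronger inhibition and higher numbers for weaker inhibition), and reports only a limit of > 100000 nM, not a number. Compound 2 `Cc1ccc(N2C(=O)C/C(=C\c3cccc(C(=O)Nc4cccc(F)c4)c3)C2=O)cc1` likewise gives only a limit, > 100000 nM, in this assay. Among the measured compounds shown here, compound 3 `CCc1cccc(NC(=O)c2cccc(/C=C3\CC(=O)N(Cc4ccccc4)C3=O)c2)c1` is the one member with a numeric value, 80600 nM in this assay. Compound 1 therefore stands where most of this small set stands: the limit of > 100000 nM in this assay, at which 2 of the 3 values shown sit. For the measured compounds named here, no pair of measured compounds differs in one place alone, so no measured step tells how the group on the amide-type nitrogen moves the reading; compound 3 merely shows that a number close to the limit can be reached.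

Compound 4 `COc1ccc(NC(=O)c2cccc(/C=C3\CC(=O)N(c4ccccc4)C3=O)c2)c(C)c1` differs from compound 1 in one place: 4-methoxy-2-methylphenyl in place of 4-ethylphenyl on an amide-type nitrogen. Nothing measured separates a change of this kind from the scatter, and with compound 1 at a limit the account can only expect compound 4 to sit in the same region, most likely reported again as a limit. For compound 4 the expected value is 110000 nM, with a range from 50000 nM to 300000 nM. This estimate is expected to mean a step that the limit leaves unreadable from compound 1 to compound 4 that stays within the scatter, in no direction beyond it.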

Compound 4, half-maximal inhibitory concentration: > 100000 nM
Compound 4: a limit, no number; the forecaster's own chance of this, stated with the estimate: 70%; the middle value lies beyond the limit too.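

Compound 1 and compound 4 are both reported only as limits, so no step can be read for 4-methoxy-2-methylphenyl in place of 4-ethylphenyl. Compound 4 joins most of this small set: the limit of > 100000 nM in this assay, at which 3 of the 4 values shown sit. The compounds shown leave open whether this change on the amide-type nitrogen alters the reading at all.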